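A phenyl group added to the ring of compound 2

This account rests on a few compounds, and the source may have more. Where it says the series, first, only, none or still open, it means among the compounds named here.

In a functional assay on HA22T cells for cytotoxicity against HA22T cell line (Homo sapiens) (on this read-out higher numbers stand for weaker inhibition and lower numbers for stronger inhibition), compound 1 (`N#C/N=C1\N(CCCCCOc2ccc(Cl)cc2)C(=O)CN1c1ccncc1`) gives 8970 nM and compound 2 (`N#C/N=C1\N(CCCCCCOc2ccc(Cl)cc2)C(=O)CN1c1ccncc1`) gives 3860 nM as the lower of the two numbers. Among the compounds with values here, the only measured step (a 2.3-fold lower number from compound 1 to compound 2 (0.37 log units; beyond the scatter)) extends the chain and is modest. Compound 3 (`N#C/N=C1\N(CCCCCCOc2ccc(Cl)cc2)C(=O)C(c2ccccc2)N1c1ccncc1`) differs from compound 2 elsewhere, with phenyl in place of hydrogen on a saturated ring carbon. Within the data shown here, no measured step touches that ring carbon, so the chain step is only a rough guide to size and gives no direction. The expected step (a 1.3-fold lower number from compound 2 to compound 3 (0.11 log units; within the scatter)) is therefore none beyond the scatter. Compound 3 is estimated at 3000 nM (expected range 700 nM to 12000 nM).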

Compound 3, half-maximal inhibitory concentration: 526 nM
The estimate for compound 3 lay 5.7-fold (0.76 log units) above the measured number; the measured number lies below the stated range.
By their numbers in this assay, from the lowest: compound 3; then compound 2; then compound 1.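

In this assay, phenyl in place of hydrogen on the saturated ring carbon gives a 7.3-fold lower number from compound 2 to compound 3 (0.87 log units; beyond the scatter). So the ring of the shared core, and not only the chain, is a place where a change moves the number, and this carbon takes a group of six carbon atoms with a gain in cytotoxicity. Nothing available explains why the number falls. Going by these compounds, whether a methyl, a benzyl or a 4-chlorophenyl group at this carbon would give a similar step stays open. So does whether phenyl has the same effect on the shorter chain of compound 1.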